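The source may report more compounds than this note shows. Statements on the series, on what has been measured and on what is new or still open speak of the compounds shown alone.

Measured so far in a functional assay on OVCAR-8 cells (Homo sapiens) for antiproliferative activity; on this read-out lower numbers stand for stronger inhibition and higher numbers for weaker inhibition:
- compound 1 `Cn1ncc(Cl)c1-c1cc(C(=O)N[C@@H]2CN[C@H](CC(O)CO)C[C@H]2c2ccc(F)c(F)c2)oc1Cl` gives 690 nM
- compound 2 `Cn1ncc(Cl)c1-c1cc(C(=O)N[C@@H]2CNCC[C@H]2c2ccc(C(F)(F)F)cc2)oc1Cl` gives 120 nM
- compound 3 `Cn1ncc(Cl)c1-c1cc(C(=O)N[C@@H]2CN[C@H](CCn3cncn3)C[C@H]2c2ccc(Cl)c(Cl)c2)oc1Cl` gives 1560 nM

Compound 3 has the highest number of the three, which makes it the weakest inhibitor in this small set. Compound 1 and compound 2 both read lower by more than the usual scatter.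

Compound 4 `CCC[C@@H]1C[C@@H](c2ccc(Cl)c(Cl)c2)[C@H](NC(=O)c2cc(-c3c(Cl)cnn3C)c(Cl)o2)CN1` has not yet been measured. It differs from compound 3 by one change: methyl in place of 1H-1,2,4-triazol-1-yl on a saturated chain carbon, two bonds along the chain from a saturated ring carbon. In words, this is methyl in place of 1H-1,2,4-triazol-1-yl on a saturated chain carbon, two bonds along the chain from a saturated ring carbon, so 2-(1H-1,2,4-triazol-1-yl)ethyl becomes propyl.

Within the data shown here, no two measured compounds differ in only one place, so nothing measured gives the size of this change directly. Compound 2 has no such chain and gives 120 nM in this assay, but it also carries a different aromatic group. Compound 1 differs in both its chain and its aromatic group and gives 690 nM in this assay as well. On this thin evidence, a moderate step to a lower number, probably beyond the scatter, is expected.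

The estimated change is a 3.5-fold lower number from compound 3 to compound 4 (0.54 log units; beyond the scatter) in this assay as a whole. For compound 4 the estimated value is 450 nM, with an expected range from 140 nM to 1400 nM.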

Compound 4, half-maximal inhibitory concentration: 1620 nM
Estimate against measurement, compound 4: 3.6-fold (0.56 log units) below; measured number above the stated range.
By their numbers in this assay, from the lowest: compound 2; then compound 1; then compounds 3 and 4 (each within the scatter of the next).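

In this assay, putting methyl in place of 1H-1,2,4-triazol-1-yl on a saturated chain carbon, two bonds along the chain from a saturated ring carbon, turns 2-(1H-1,2,4-triazol-1-yl)ethyl into propyl and gives a 1.0-fold higher number from compound 3 to compound 4 (0.02 log units; within the scatter). Among these compounds, this is the first measured pair that differs in only one place, so it gives a direct reading of this change: in this pair, a five-membered aromatic ring with its 3 hydrogen-bond acceptors gives way to a single carbon, and the read-out shows no difference beyond the usual scatter. There is no evidence here to explain why the two groups read alike.

Still open, on these data alone, is whether this position would respond the same way to other groups, such as an amine or a carboxylic acid in place of the methyl, or a longer chain, and whether the same change would read alike with a different aromatic group on the ring. Also open, as far as these compounds go, is what hydrogen in place of the propyl chain would do while everything else in compound 4 stays the same.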